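Fluoro replaces methoxy on the benzyl ring of compound 3

A few compounds are considered here, and "the series" means these few. Any claim that something is new, unique, unknown or untested is made for them only; others in the source may bear on it.

Measured compounds:
compound 1 `Cc1cc(N2CC[C@@H](C)[C@@H](N(C)c3ncnc4[nH]ccc34)C2)n2nc(SCc3ccc(C(F)(F)F)cc3)nc2n1`: 2680 nM
compound 2 `Cc1cc(N2CC[C@@H](C)[C@@H](N(C)c3ncnc4[nH]ccc34)C2)n2nc(SCc3ccc([N+](=O)[O-])cc3)nc2n1`: 27000 nM
compound 3 `COc1ccc(CSc2nc3nc(C)cc(N4CC[C@@H](C)[C@@H](N(C)c5ncnc6[nH]ccc56)C4)n3n2)cc1`: 15200 nM

Three compounds share one core and differ only in the group on the benzyl ring. In a functional assay on MGC-803 cells (Homo sapiens) for inhibition, read by MTT assay, with a stated time of 72 h (a lower number here means a stronger inhibitor, a higher number a weaker inhibitor), compound 1 gives 2680 nM, compound 2 gives 27000 nM and compound 3 gives 15200 nM. Compound 3 thus has the second highest number of the three: its gap to compound 2 is within the scatter, while its gap to compound 1 is beyond it (a 5.7-fold higher number from compound 1 to compound 3 (0.75 log units; beyond the scatter)).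

Compound 4 `Cc1cc(N2CC[C@@H](C)[C@@H](N(C)c3ncnc4[nH]ccc34)C2)n2nc(SCc3ccc(F)cc3)nc2n1` is the next step. Its change from compound 3 is fluoro in place of methoxy on an aromatic carbon.

Among the measured compounds shown here, none of the measured steps exchanges methoxy for fluoro, so no step bears on this change directly. The measured steps show that the group on this ring matters: a 10-fold higher number from compound 1 to compound 2 (1.00 log units; beyond the scatter) and a 5.7-fold higher number from compound 1 to compound 3 (0.75 log units; beyond the scatter), whereas a 1.8-fold lower number from compound 2 to compound 3 (0.25 log units; within the scatter). Compound 4 is therefore expected to land somewhere between compound 1 and compound 3, with the step of a 2.2-fold lower number from compound 3 to compound 4 (0.34 log units; beyond the scatter) estimated, and wide uncertainty. The estimate for compound 4 in this assay is 7000 nM, within 2500 nM to 20000 nM.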

Compound 4, half-maximal inhibitory concentration: 11900 nM
Estimate against measurement, compound 4: 1.7-fold (0.23 log units) below; the measured number falls inside the stated range.
By their numbers in this assay, from the lowest: compound 1; then compounds 4, 3 and 2 (each within the scatter of the next, the first and the last beyond it).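

In this assay, fluoro in place of methoxy gives a 1.3-fold lower number from compound 3 to compound 4 (0.11 log units; within the scatter), so this exchange on the benzyl ring does not separate the two compounds. Fluoro does separate from nitro, with a 2.3-fold lower number from compound 2 to compound 4 (0.36 log units; beyond the scatter), but it does not reach trifluoromethyl, with a 4.4-fold higher number from compound 1 to compound 4 (0.65 log units; beyond the scatter), and compound 1 remains the strongest inhibitor of the four. The data shown offer no explanation for this ordering.

Going by these compounds, whether a chloro group, a nitrile or a carboxylic acid in this place would match trifluoromethyl remains open. Also open, on these data alone, is whether the lead of compound 1 depends on its fluorine atoms, a question that a methyl group in the same place could help to answer.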